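Carboxymethoxy in place of the basic ether chain

The source may report more compounds than this note shows. Statements on the series, on what has been measured and on what is new or still open speak of the compounds shown alone.

Compound 1, `COc1ccc(C(c2ccc(OC(C)CN(C)C)cc2)c2cccc3ccccc23)c(OC)c1OC`, gives 4340 nM in a functional assay on MDA-MB-231 cells (Homo sapiens) for inhibition, read by sulforhodamine B assay, with a stated time of 48 h (on this read-out higher numbers stand for weaker inhibition and lower numbers for stronger inhibition), and holds the lowest of the two numbers on record. Compound 3, `COc1ccc(C(O)(C/C=C\c2ccccc2)c2cccc3ccccc23)c(OC)c1OC`, gives 12800 nM, a gap beyond the scatter. Compound 2, `C=CCC(O)(c1ccc(OC)c(OC)c1OC)c1cccc2ccccc12`, reaches only a limit of this assay at > 20000 nM, so the limit of > 20000 nM in this assay, at which 1 of the 3 values shown sits, applies there and no number is known for it. Within the data shown here, the one step measured within this set, an at least 1.5-fold lower number from compound 2 to compound 3 (0.19 log units; that floor lies within the scatter), concerns the carbinol carbon of the shared core and not the aryl ether.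

The new compound 4, `COc1ccc(C(c2ccc(OCC(=O)O)cc2)c2cccc3ccccc23)c(OC)c1OC`, differs from compound 1 only at that ether oxygen: carboxymethyl in place of 1-((dimethylamino)methyl)ethyl on an oxygen on an aromatic ring. Among the measured compounds shown here, no measured step touches this group, so nothing recorded speaks directly to its size or direction. For the measured compounds named here, the only guidance is the standing of compound 1 itself as the lowest number in this assay. Going by the values given here, with no supporting step, the expectation for compound 4 is a higher number than compound 1, with wide uncertainty that reaches the limit of this assay.

Compound 4 is therefore estimated at 12000 nM, between 4000 nM and 30000 nM. The expected step is a 2.8-fold higher number from compound 1 to compound 4 (0.44 log units; beyond the scatter).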

Compound 4, half-maximal inhibitory concentration: > 20000 nM
Compound 4 ended at the assay's limit; the forecaster's own chance of this, stated with the estimate: 35%; middle value at least 1.6-fold (0.22 log units) away from the limit.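

The ether oxygen on the shared core now has its first reading in this assay: carboxymethyl in place of 1-((dimethylamino)methyl)ethyl on an oxygen on an aromatic ring gives an at least 4.6-fold higher number from compound 1 to compound 4 (0.66 log units; beyond the scatter). Among these compounds, the only earlier step concerned the carbinol carbon and had a floor within the scatter, so this is the first change in the set with a step beyond it, and it shows that the group on this oxygen matters to the number in this assay. The size of the step is a floor and not a measured gap, since compound 4 stands at a limit of the assay: the limit of > 20000 nM in this assay, at which 2 of the 4 values shown sit.

The swap removes the dimethylamino nitrogen and introduces the carboxyl group in a single change, so the step cannot be divided between the loss of one and the gain of the other. From the compounds shown here alone, it remains open whether a primary amide or methyl ester on the same oxygen, or a longer chain ending in dimethylamino, would stay near the value of compound 1 or move towards the limit.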